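Working notes: fluoro-to-hydrogen step, cytotoxicity in MDCK

This account rests on a few compounds, and the source may have more. Where it says the series, first, only, none or still open, it means among the compounds named here.

Measured compounds:
compound 1, `CCCCCCCCCC(=O)Oc1ccc(COP(=O)(OCc2ccc(OC(=O)CCCCCCCCC)cc2)OP(=O)(O)OC[C@H]2O[C@@H](n3ccnc(C(N)=O)c3=O)[C@H](O)[C@@H]2O)cc1`: 37000 nM
compound 2, `CCCCCCCCCCCCCCC(=O)Oc1ccc(COP(=O)(OCc2ccc(OC(=O)CCCC)cc2)OP(=O)(O)OC[C@H]2O[C@@H](n3cc(F)nc(C(N)=O)c3=O)[C@H](O)[C@@H]2O)cc1`: 21000 nM
compound 3, `CCCCCCCCCCCCCCC(=O)Oc1ccc(COP(=O)(OCc2ccc(OC(=O)CCCC)cc2)OP(=O)(O)OP(=O)(O)OC[C@H]2O[C@@H](n3ccnc(C(N)=O)c3=O)[C@H](O)[C@@H]2O)cc1`: 16000 nM

All three numbers come from an ADME assay on MDCK cells (Canis lupus familiaris) for cytotoxicity, read by microscopy, with a stated time of 3 days; on this read-out higher numbers stand for lower toxicity in this test and lower numbers for higher toxicity in this test. Compound 2 stands second highest of the three. Its nearest neighbour is compound 3, whose value 16000 nM lies within the scatter of compound 2. The furthest is compound 1, whose value 37000 nM is also within the scatter. Among the measured compounds shown here, on these three numbers the series is flat: no pair is separated by more than the usual scatter, so none of the three can be called the least or the most toxic in this assay.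

Compound 4, `CCCCCCCCCCCCCCC(=O)Oc1ccc(COP(=O)(OCc2ccc(OC(=O)CCCC)cc2)OP(=O)(O)OC[C@H]2O[C@@H](n3ccnc(C(N)=O)c3=O)[C@H](O)[C@@H]2O)cc1`, has not yet been measured. It differs from compound 2 in a single place: hydrogen in place of fluoro on an aromatic carbon. For the measured compounds named here, no measured pair shows this exact change, so its size cannot be read from the data. Given that all measured compounds sit within the scatter of one another, no step beyond the scatter is expected in this assay from compound 2 to compound 4. The estimate for compound 4 is 21000 nM, with a range from 10000 nM to 45000 nM. This estimate means an expected step of no change at the digits printed from compound 2 to compound 4 (within the scatter).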

Compound 4, minimum cytotoxic concentration: 21000 nM
Estimate against measurement, compound 4: no gap at the digits printed, and the stated range covers the measured number.
By their numbers in this assay, from the lowest: compounds 3, 2, 4 and 1 (each within the scatter of the next, the first and the last beyond it).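

Hydrogen in place of fluoro on an aromatic carbon, next to the ring nitrogen of the six-membered aromatic ring, gives no change at the digits printed from compound 2 to compound 4 (within the scatter) in this assay with the rest of the structure unchanged. Among the compounds shown here, the earlier compounds held no pair differing in one place, and this step is the first direct reading of any single change: at this position, the fluoro group can be removed with no difference that stands out from the scatter on minimum cytotoxic concentration. Nothing measured here bears on why the step is flat.

Still open, on these data alone, is whether this position tolerates other groups in the same way, such as an amine, a chlorine atom, a nitrile or a carboxylic acid, since fluoro and hydrogen are the only two seen here on an otherwise identical structure. Also open, as far as these compounds go, is whether the same fluoro-to-hydrogen step stays flat with a longer chain on the ester groups, or on a core carrying a different phosphate linkage, as a single pair says nothing about other settings.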